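The source may hold more compounds than are shown below. What is called first, only, known or untested is meant among the compounds shown, and "the series" means these compounds.

In a functional assay on MGC-803 cells (Homo sapiens) for inhibition, read by MTT assay, with a stated time of 72 h (a lower number here means a stronger inhibitor, a higher number a weaker inhibitor), compound 1 `CC(C)c1ccc(-c2nc(SCc3cn(CC(=O)NC(=O)Nc4ccccn4)nn3)nc(Nc3ccccc3Cl)c2C#N)cc1` gives 19700 nM. Compound 2 `CC(C)c1ccc(-c2nc(SCc3cn(CC(=O)NC(=O)Nc4ccccn4)nn3)nc(Nc3cccc(Cl)c3)c2C#N)cc1` differs from it only in the aniline, and in this assay compound 2 reaches only the limit of > 64000 nM. The step of an at least 3.2-fold higher number from compound 1 to compound 2 (0.51 log units; beyond the scatter) is therefore readable only as a lower bound. Compound 3 `CC(C)c1ccc(-c2nc(SCc3cn(CC(=O)NC(=O)Nc4ccccn4)nn3)nc(Nc3ccccc3F)c2C#N)cc1` carries a 2-fluorophenyl group, and in this assay compound 3 likewise sits at the limit of > 64000 nM. The step of an at least 3.2-fold higher number from compound 1 to compound 3 (0.51 log units; beyond the scatter) is again a bound, and the step that the two limits leave unreadable from compound 2 to compound 3 cannot be read, since both ends sit at the limit of > 64000 nM in this assay, at which 2 of the 3 values shown sit. Compound 3 thus stands at the weak end of the numbers shown, together with compound 2, and only compound 1 gives a number.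

Compound 4 `Cc1cccc(Nc2nc(SCc3cn(CC(=O)NC(=O)Nc4ccccn4)nn3)nc(-c3ccc(C(C)C)cc3)c2C#N)c1` takes the change (3-methylphenyl in place of 2-fluorophenyl on a nitrogen on an aromatic ring). The measured steps that bear on this are those away from compound 1, both at least modest and both toward weaker inhibition, with the 3-chlorophenyl analogue compound 2 already at the limit. Compound 4 is therefore expected to remain near the limit, with the step of a number no higher from compound 3 to compound 4 (the limit leaves the size open) expected to be small or unreadable. The estimate for compound 4 in this assay is 64000 nM, in the range 20000 nM to 200000 nM.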

Compound 4, half-maximal inhibitory concentration: 25300 nM
For compound 4 the middle estimate is 2.5-fold (0.40 log units) above the measured one; measured number inside the range.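

In this assay, going by these compounds alone, 3-methylphenyl is the first group on this nitrogen besides 2-chlorophenyl to give a number rather than a limit, and a 1.3-fold higher number from compound 1 to compound 4 (0.11 log units; within the scatter) means that the two compounds cannot be told apart. A 3-substituted phenyl ring is therefore not itself enough to leave a compound at the limit: exchanging chloro for methyl gives an at least 2.5-fold lower number from compound 2 to compound 4 (0.40 log units; beyond the scatter), and the exchange from the fluorinated ring gives an at least 2.5-fold lower number from compound 3 to compound 4 (0.40 log units; beyond the scatter). Both of these steps are bounds only, because their starting compounds sit at a limit: the limit of > 64000 nM in this assay, at which 2 of the 4 values shown sit.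

The compounds shown leave open whether 2-methylphenyl, or a methoxy or trifluoromethyl group on this phenyl ring, would give a lower number than these two compounds. They also leave open how far compound 2 and compound 3 truly lie from the rest.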